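Swapping the Aromatic End Group: Compound 2 to Compound 3

The source may report more compounds than this note shows. Statements on the series, on what has been measured and on what is new or still open speak of the compounds shown alone.

Compound 2, `COc1ccc(C(=O)/C=C/c2ccc([N+](=O)[O-])cc2)c2c1C=CC(C)(C)O2`, gives 7770 nM in a functional assay on K562 cells (Homo sapiens) for antiproliferative activity, read by MTT assay, with a stated time of 24 h; a higher number here means a weaker inhibitor, a lower number a stronger inhibitor. That is the only number shown so far; the one other result is a limit rather than a number. Compound 1, `COc1ccc(C(=O)/C=C/c2ccc(-n3ccnc3)cc2)c2c1C=CC(C)(C)O2`, returns a limit in this assay, > 10000 nM. For the measured compounds named here, the single measured step, an at least 1.2-fold lower number from compound 1 to compound 2 (0.10 log units; that floor lies within the scatter), puts nitro in place of 1H-imidazol-1-yl on an aromatic carbon, and its size rests on (the limit of > 10000 nM in this assay, at which 1 of the 2 values shown sits). Compound 3, `COc1ccc(C(=O)/C=C/c2ccc(O)c(Br)c2)c2c1C=CC(C)(C)O2`, differs from compound 2 by 3-bromo-4-hydroxyphenyl in place of 4-nitrophenyl on a double-bonded chain carbon bound to a double-bonded chain carbon. Going by the values given here, no measured step changes this part of the molecule with a number on both sides, so there is no basis to expect a shift beyond the scatter, and the expected step of a 1.0-fold higher number from compound 2 to compound 3 (0.01 log units; within the scatter) is small. Compound 3 is therefore estimated at about 8000 nM, within 2000 nM to 40000 nM, with a fair chance that this assay reports only a limit.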

Compound 3, half-maximal inhibitory concentration: > 10000 nM
Compound 3: no number, only a limit (the forecaster's own chance of this, stated with the estimate: 40%); at least 1.2-fold (0.09 log units) between middle value and limit.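

In this assay compound 3 gives > 10000 nM, which is a limit of the assay and not a number. Replacing the 4-nitrophenyl group with 3-bromo-4-hydroxyphenyl therefore gives only a floor, an at least 1.2-fold higher number from compound 2 to compound 3 (0.10 log units; that floor lies within the scatter), and the true size of the change stays unknown, so this step cannot separate the two compounds: the limit of > 10000 nM in this assay, at which 2 of the 3 values shown sit.

Compound 3 now joins compound 1 at that limit, which leaves compound 2 as the only one of the three with a measured number.

From the compounds shown here alone, whether an amine or a carboxylic acid on this aromatic ring would give a clearly lower number than compound 2 remains open. Also open, going by these compounds, is what the bromine and the hydroxyl of compound 3 would each do alone.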